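Piperazine side-chain homologation in a benzothiazole amide series

A few compounds are considered here, and "the series" means these few. Any claim that something is new, unique, unknown or untested is made for them only; others in the source may bear on it.

Measured compounds:
compound 1 `CCCCN1CCN(CCC(=O)Nc2nc3c(C)cccc3s2)CC1` — in an assay on HEK293 cells for antagonist activity at P2X purinoceptor 7 (Homo sapiens), read by fluorescence, with stated times of 30 min and 120 min (a higher number here means a weaker inhibitor, a lower number a stronger inhibitor), compound 1 gives no result reported
compound 2 `Cc1cccc2sc(NC(=O)CCN3CCN(CCN(C)C)CC3)nc12` — this assay: 2150 nM

Within the data shown here, compound 2 is the only member with a number in this assay; compound 1 carries no result there, so compound 2 cannot be placed against anything. The move to compound 3 `Cc1cccc2sc(NC(=O)CCN3CCN(CCCN(C)C)CC3)nc12` is (dimethylamino)methyl in place of dimethylamino on a saturated chain carbon, two bonds along the chain from an amine nitrogen in a ring. Among the measured compounds shown here, no measured pair shows this kind of change, so its size is not known from this set. With nothing to lean on beyond the value of compound 2, compound 3 is expected to stay within the scatter, a step of a 1.1-fold lower number from compound 2 to compound 3 (0.03 log units; within the scatter), and its estimate in this assay is 2000 nM, with a range from 800 nM to 5000 nM.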

Compound 3, half-maximal inhibitory concentration: 18100 nM
For compound 3 the middle estimate is 9.1-fold (0.96 log units) below the measured one, outside the stated range (above it).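

In this assay this saturated chain carbon is sensitive to small changes: (dimethylamino)methyl in place of dimethylamino gives an 8.4-fold higher number from compound 2 to compound 3 (0.93 log units; beyond the scatter), so the number rises with this one change in the side chain. Among these compounds, compound 1 has no value, so no step involving it can be read. No measurement at hand explains the rise.

On these data alone, whether a longer chain such as 3-(dimethylamino)propyl would raise the number further remains open. So does whether a ring amine such as morpholine at the chain end would hold the value of compound 2 or lower it.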